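The source may report more compounds than this note shows. Statements on the series, on what has been measured and on what is new or still open speak of the compounds shown alone.

Measured compounds:
compound 1, `C[C@H](Nc1ncnc2[nH]cnc12)c1nn(-c2cccc(F)c2)c2cc(F)ccc12`, 33%
compound 2, `C[C@H](Nc1ncnc2[nH]cnc12)c1nn(-c2cccc(S(C)(=O)=O)c2)c2cc(F)ccc12`, 23%

This account follows the step from compound 2 to the not yet measured compound 3, `C[C@H](Nc1ncnc2[nH]cnc12)c1nn(-c2ccncc2)c2cc(F)ccc12`. In a functional assay on HepG2 cells (Homo sapiens) for inhibition, read by sulforhodamine B assay, with a stated time of 72 h, tested at 10 uM (on this read-out higher numbers stand for more inhibition at the one concentration tested (going by the name of the read-out) and lower numbers for less inhibition), compound 2 gives 23%, the lowest of the two numbers at hand. For the measured compounds named here, its only neighbour is compound 1, which in this assay gives 33%; the step of a number 10 percentage points lower from compound 1 to compound 2 (within the scatter) is within the usual scatter, so the two compounds cannot be told apart on this read-out.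

The change from compound 2 to compound 3 is pyridin-4-yl in place of 3-(methylsulfonyl)phenyl on an aromatic nitrogen. Going by the values given here, the one measured step that touches the same aromatic nitrogen-bound ring, a number 10 percentage points lower from compound 1 to compound 2 (within the scatter), was small, and the two compounds it joins are indistinguishable on the numbers. Among the compounds with values here, no measured step exchanges a carbon-only ring for a ring bearing a ring nitrogen, so there is nothing to point to a change in either direction beyond the scatter. The expected step of a number 5 percentage points higher from compound 2 to compound 3 (within the scatter) is therefore taken to be small, with wide uncertainty. For compound 3 the estimate in this assay is 28%, expected to fall between 10% and 46%.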

Compound 3, a percentage reported as inhibition, at one concentration (the size of the read-out at that concentration, not a potency): 47%
Compound 3: middle estimate off by 19 percentage points, on the low side, and the stated range ends below it.
By their numbers in this assay, from the lowest: compounds 2 and 1 (each within the scatter of the next); then compound 3.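

At the aromatic nitrogen of the five-membered ring, this assay does respond to the group placed there: pyridin-4-yl in place of 3-(methylsulfonyl)phenyl gives a number 24 percentage points higher from compound 2 to compound 3 (beyond the scatter) and pyridin-4-yl in place of 3-fluorophenyl gives a number 14 percentage points higher from compound 1 to compound 3 (beyond the scatter) on the same shared core. For the compounds shown here, the two compounds with a carbon-only ring could not be told apart, so this is the first change at this position to exceed the scatter, and compound 3, the only one here with a hetero atom in that ring, lies clearly above both of them, although a single compound establishes no general pattern. Nothing available gives a reason for this difference.

Going by these compounds, whether the ring nitrogen itself or its place in the ring goes with the higher number remains open, and a pyridin-3-yl or pyridin-2-yl group at this position would bear on that question. On these data alone, it is also open whether an amine or a carboxylic acid on the pyridin-4-yl ring would move the number further, and how compound 3 would rank as a potency, given that the read-out is taken at one concentration.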